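Nitrophenyl isomers in the series: compound 3 and compound 4

The compounds below may be only part of what the source reports. "The series", "measured", "known", "first", "only" and "open" are said of these compounds alone.

Measured in a functional assay on HuCC-A1 cells (Homo sapiens) for cytotoxicity, read by crystal violet staining, with a stated time of 3 days; on this read-out lower numbers stand for stronger inhibition and higher numbers for weaker inhibition:
compound 1 `COc1cc2c(cc1OC)C(/C(C)=N/NC(N)=S)N(S(=O)(=O)c1ccc(C)cc1)CC2`: > 50 ug/mL
compound 2 `COc1ccc(S(=O)(=O)N2CCc3cc(OC)c(OC)cc3C2/C(C)=N/NC(N)=S)cc1`: 31 ug/mL
compound 3 `C/C(=N\NC(N)=S)C1c2ccccc2CCN1S(=O)(=O)c1ccc([N+](=O)[O-])cc1`: > 50 ug/mL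

The values with a sign are limits of the assay, not numbers. Compound 3 stands at the limit of > 50 ug/mL in this assay, at which 2 of the 3 values shown sit. Compound 4 `C/C(=N\NC(N)=S)C1c2ccccc2CCN1S(=O)(=O)c1cccc([N+](=O)[O-])c1` differs from compound 3 by 3-nitrophenyl in place of 4-nitrophenyl on a sulfonyl sulfur. For the measured compounds named here, no measured step involves a nitrophenyl group. The only one, an at least 1.6-fold lower number from compound 1 to compound 2 (0.20 log units; that floor lies within the scatter), comes with methoxy in place of methyl on an aromatic carbon, so it bears only loosely on this change. No step beyond the scatter is therefore expected in this assay. The expected result is an at least 1.1-fold lower number from compound 3 to compound 4 (0.04 log units; that floor lies within the scatter). For compound 4 the estimate is 45 ug/mL, with an expected range from 22 ug/mL to 90 ug/mL.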

Compound 4, half-maximal inhibitory concentration: > 50 ug/mL
Compound 4 ended at the assay's limit; the forecaster's own chance of this, stated with the estimate: 65%; middle value at least 1.1-fold (0.04 log units) from the limit.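

Compound 3 and compound 4 both end at a limit of this assay, so no step between them can be read: the limit of > 50 ug/mL in this assay, at which 3 of the 4 values shown sit.

The compounds shown leave open whether 3-nitrophenyl in place of 4-nitrophenyl on a sulfonyl sulfur changes the read-out at all.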